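Sulfonyl aryl change on the methyl-chain sulfonamide

This account rests on a few compounds, and the source may have more. Where it says the series, first, only, none or still open, it means among the compounds named here.

Three compounds have numbers in a functional assay on HeLa cells (Homo sapiens) for cytotoxicity, read by sulforhodamine B assay (on this read-out higher numbers stand for weaker inhibition and lower numbers for stronger inhibition), so far. Compound 1 `Cc1ccccc1S(=O)(=O)NC(C1=CC(=O)c2c(O)ccc(O)c2C1=O)C(C)C` gives 790 nM and is the lowest of them. Compound 2 `CC(C)C(NS(=O)(=O)c1ccccc1Br)C1=CC(=O)c2c(O)ccc(O)c2C1=O` gives 8310 nM on the same read-out. Compound 3 `Cc1ccccc1S(=O)(=O)NC(C)C1=CC(=O)c2c(O)ccc(O)c2C1=O` stands at 4490 nM within the scatter of compound 2 and clearly above compound 1.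

Compound 4 `CC(NS(=O)(=O)c1cccc(Br)c1)C1=CC(=O)c2c(O)ccc(O)c2C1=O` differs from compound 3 as follows: 3-bromophenyl in place of 2-methylphenyl on a sulfonyl sulfur.

The nearest measured evidence is an 11-fold higher number from compound 1 to compound 2 (1.02 log units; beyond the scatter) for bromo in place of methyl on an aromatic carbon. Among the compounds with values here, that step is large and points upward, but it was measured on the isopropyl compound, and no measured compound carries the 3-bromophenyl group. The other relevant step is a 5.7-fold higher number from compound 1 to compound 3 (0.75 log units; beyond the scatter) for methyl in place of isopropyl on the chain. It is modest, does not touch the sulfonyl aryl group, and leaves compound 3 already high on the scale.

Only part of the large bromo step is therefore expected to carry over, in the same upward direction. The expected step is a 1.8-fold higher number from compound 3 to compound 4 (0.25 log units; within the scatter) and would stay within the scatter. Compound 4 is estimated at 8000 nM with an expected range from 2500 nM to 25000 nM on this evidence.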

Compound 4, half-maximal inhibitory concentration: 6350 nM
Estimate against measurement, compound 4: 1.3-fold (0.10 log units) above; low and high end bracket the measured number.
By their numbers in this assay, from the lowest: compound 1; then compounds 3, 4 and 2 (each within the scatter of the next).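

In this assay, the change from 2-methylphenyl to 3-bromophenyl on the sulfonyl sulfur gives a 1.4-fold higher number from compound 3 to compound 4 (0.15 log units; within the scatter), so compound 3 and compound 4 cannot be told apart on this read-out. Within the data shown here, this is the first direct reading of a change to the sulfonyl aryl group on the methyl-chain compounds, and it shows that this replacement leaves the number within the scatter, whereas the step on the isopropyl compounds, an 11-fold higher number from compound 1 to compound 2 (1.02 log units; beyond the scatter), is large; those two steps differ in both the chain and the aryl group, so the contrast cannot be assigned to either alone. No available evidence bears on the origin of this result.

Still open, as far as these compounds go, is how the 3-bromophenyl group behaves with isopropyl on the chain, which would show whether the chain and the aryl group act independently. Also open, from the compounds shown here alone, is whether an amine or a carboxylic acid on the sulfonyl aryl ring, or a longer chain in place of methyl, moves the number beyond the scatter.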